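Thiophene for phenyl on two ribonucleoside cores

The source may hold more compounds than are shown below. What is called first, only, known or untested is meant among the compounds shown, and "the series" means these compounds.

Compound 1 `CSc1ncnc2c1c(-c1ccccc1)cn2[C@@H]1O[C@H](CO)[C@@H](O)[C@H]1O` and compound 2 `CSc1ncnc2c1c(-c1ccsc1)cn2[C@@H]1O[C@H](CO)[C@@H](O)[C@H]1O` share one core; compound 3 `Nc1nc2c(c(-c3ccccc3)cn2[C@@H]2O[C@H](CO)[C@@H](O)[C@H]2O)c(=O)[nH]1` and the not yet measured compound 4 `Nc1nc2c(c(-c3ccsc3)cn2[C@@H]2O[C@H](CO)[C@@H](O)[C@H]2O)c(=O)[nH]1` share another. The difference between the two cores is not broken down here. In a functional assay on HeLa S3 cells (Homo sapiens) for antiproliferative activity, read by XTT assay, with a stated time of 72 h (a higher number here means a weaker inhibitor, a lower number a stronger inhibitor), compound 1 gives only a limit, > 20000 nM. In this assay compound 2 likewise gives a limit, > 20000 nM. The change between them, (thiophen-3-yl in place of phenyl on an aromatic carbon), gave a step that the two limits leave unreadable from compound 1 to compound 2, because both values sit at the limit of > 20000 nM in this assay, at which 3 of the 3 values shown sit. In this assay compound 3 also gives a limit, > 20000 nM. The same change is now made on the second core, (thiophen-3-yl in place of phenyl on an aromatic carbon), with the place described in the same words. The step from compound 3 to compound 4 is expected to be a step that the limit leaves unreadable from compound 3 to compound 4, resting on the limit of compound 3, > 20000 nM, and on the unreadable step that the two limits leave unreadable from compound 1 to compound 2, which gives no direction for the change. For compound 4 in this assay the estimate is 30000 nM, within 8000 nM to 100000 nM, most likely reported only as a limit.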

Compound 4, half-maximal inhibitory concentration: > 20000 nM
Compound 4: a limit, no number; the forecaster's own chance of this, stated with the estimate: 85%; the middle value is on the limit's open side.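

No step can be read from compound 3 to compound 4, and the same holds for the earlier pair, compound 1 and compound 2, because all four values are limits: the limit of > 20000 nM in this assay, at which 4 of the 4 values shown sit.

The compounds shown leave open whether thiophen-3-yl in place of phenyl changes antiproliferative activity on either core.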